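Moving a fluorine on the pendant ring of compound 3

The source may hold more compounds than are shown below. What is called first, only, known or untested is meant among the compounds shown, and "the series" means these compounds.

Three compounds sharing one core have been run in an ADME assay on microsomes from liver (Homo sapiens) for metabolic stability, tested at 2.5 uM; on this read-out higher numbers stand for fast clearance and lower numbers for slow clearance. Compound 1 `COc1ccc(S(=O)(=O)c2cnc3cc(F)ccc3c2-c2ccc(F)cc2)cc1Cl` gives 1.29 mL/min. Compound 2 `O=S(=O)(c1cccc(F)c1)c1cnc2cc(F)ccc2c1-c1ccc(F)cc1` gives 0.11 mL/min. Compound 3 `COc1ccc(S(=O)(=O)c2cnc3cc(F)ccc3c2-c2cccc(F)c2)cc1` gives 2.94 mL/min, the highest of the three numbers; its nearest neighbour is compound 1, and its furthest is compound 2, both gaps lying beyond the scatter.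

The next compound, compound 4 `COc1ccc(S(=O)(=O)c2cnc3cc(F)ccc3c2-c2ccc(F)cc2)cc1`, differs from compound 3 only in where the fluorine sits on the pendant ring: 4-fluorophenyl in place of 3-fluorophenyl on an aromatic carbon.

Going by the values given here, the one measured step, a 12-fold lower number from compound 1 to compound 2 (1.07 log units; beyond the scatter), concerns the aryl group on the sulfonyl sulfur and leaves the pendant ring untouched, so it does not bear directly on this change. Compound 1 and compound 4 share the same 4-fluorophenyl, and compound 1 sits closer to compound 3 than compound 2 does. Taken together these numbers give no clear direction for the change from compound 3 to compound 4; a step of modest size, if any, is expected, a 1.5-fold lower number from compound 3 to compound 4 (0.17 log units; within the scatter).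

Compound 4 is therefore estimated to give 2 mL/min in this assay, with a range from 0.9 mL/min to 4.5 mL/min.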

Compound 4, intrinsic clearance in a liver preparation (reported as CLH), per the amount of preparation that the assay uses: 1.71 mL/min
Estimate against measurement, compound 4: 1.2-fold (0.07 log units) above; the measured number falls inside the stated range.
By their numbers in this assay, from the lowest: compound 2; then compounds 1, 4 and 3 (each within the scatter of the next, the first and the last beyond it).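

In this assay, going by these compounds alone, moving the fluorine around the pendant ring gives a 1.7-fold lower number from compound 3 to compound 4 (0.24 log units; within the scatter), the first direct reading at this position, and it shows that 4-fluorophenyl and 3-fluorophenyl cannot be told apart here. With the pendant 4-fluorophenyl held fixed, the large change lies on the sulfonyl sulfur: 4-methoxyphenyl in place of 3-fluorophenyl gives a 16-fold higher number from compound 2 to compound 4 (1.19 log units; beyond the scatter), whereas hydrogen in place of chloro gives only a 1.3-fold higher number from compound 1 to compound 4 (0.12 log units; within the scatter), so the chloro group of compound 1 makes no difference beyond the scatter. Nothing measured here explains any of these steps.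

The compounds shown leave open whether the fluorine move would read the same with 3-fluorophenyl on the sulfonyl sulfur, where compound 2 gives the lowest number of the set, 0.11 mL/min. They also leave open whether the pendant ring tolerates anything other than a single fluorine, such as a methoxy group, a nitrile or an amine, as quietly as it tolerates this shift.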